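The source may hold more compounds than are shown below. What is called first, only, known or untested is meant among the compounds shown, and "the series" means these compounds.

Working notes on the series. Two compounds carry numbers in a functional assay on SF-295 cells (Homo sapiens) for inhibition, read by sulforhodamine B assay, with a stated time of 48 h; on this read-out higher numbers stand for lower toxicity in this test and lower numbers for higher toxicity in this test. Compound 1 `Nc1cc(N)c2nc(-c3ccccc3)c(Oc3ccc(Cl)c(Cl)c3)nc2c1` gives 69200 nM in this assay. Compound 2 `COc1cc(CNc2nc3cc(N)cc(N)c3nc2-c2ccccc2)cc(OC)c1OC` gives 37200 nM in this assay. Going by the values given here, the two numbers sit within the scatter of each other, so compound 1 is not separated from compound 2 on this read-out, and the series so far offers no change that has moved the number beyond the scatter.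

Compound 3 `Nc1cc(N)c2nc(-c3ccccc3)c(Sc3ccc(Cl)c(Cl)c3)nc2c1` is not yet measured in this assay. It is reached from compound 1 by one change: (3,4-dichlorophenyl)sulfanyl in place of 3,4-dichlorophenoxy on an aromatic carbon. The rest of compound 1 is kept. Among the compounds with values here, no pair of measured compounds shows what an exchange of the oxygen link for a sulfur link does to this read-out, so nothing measured here speaks for or against a shift.

The expectation for compound 3 is therefore a step from compound 1 of no more than the scatter, a 1.2-fold lower number from compound 1 to compound 3 (0.06 log units; within the scatter), in no fixed direction. Compound 3 is estimated at 60000 nM in this assay, with a range from 25000 nM to 150000 nM.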

Compound 3, concentration lethal to 50% of the cells: < 100000 nM
Compound 3 gave a limit, no number (the forecaster's own chance of this, stated with the estimate: 10%); the middle value is on the limit's open side.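

In this assay compound 3 gives < 100000 nM, which is a limit of the assay and not a number, so no step from compound 1 to compound 3 can be read: the limit of < 100000 nM in this assay, at which 1 of the 3 values shown sits.

The compounds shown leave open what (3,4-dichlorophenyl)sulfanyl in place of 3,4-dichlorophenoxy does to this read-out, in size and in direction.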